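The source may report more compounds than this note shows. Statements on the series, on what has been measured and on what is new or still open speak of the compounds shown alone.

Of the compounds shown here, two sharing the same core have been measured in a functional assay on MG-63 cells (Homo sapiens) for inhibition, read by CCK-8 assay, with a stated time of 72 h, tested at 1 uM; on this read-out lower numbers stand for less inhibition and higher numbers for more inhibition at the one concentration tested (going by the name of the read-out). Compound 1 `COc1ccccc1N1C(=O)CSC1c1cc(F)cc(C(=O)O)c1` gives 0% in this assay. Compound 2 `COc1cccc(OC)c1N1C(=O)CSC1c1cccc(C(=O)NCCCCc2ccccc2)c1` gives 80% in this assay, the highest of the two numbers; its nearest neighbour is compound 1, a number far lower, well beyond the scatter. The two differ in several places at once, so no single change can be tied to that gap. Compound 3 `O=C(NCCCCc1ccccc1)c1cccc(C2SCC(=O)N2c2ccccc2F)c1` has not yet been measured. It differs from compound 2 in one place: 2-fluorophenyl in place of 2,6-dimethoxyphenyl on an amide-type nitrogen in a ring. Everything else in compound 2 is kept. Among the compounds with values here, with no comparable step measured, the size of this change is uncertain; a modest loss is expected, a number 15 percentage points lower from compound 2 to compound 3 (beyond the scatter), though it could also turn out to be none beyond the scatter. Compound 3 is expected to give about 65% in this assay, somewhere between 30% and 90%.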

Compound 3, a percentage reported as inhibition, at one concentration (the size of the read-out at that concentration, not a potency): 92%
Beside the measured number, compound 3's estimate is 27 percentage points below it; measured number above the stated range.
By their numbers in this assay, from the lowest: compound 1; then compound 2; then compound 3.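

Within the data shown here, compound 3 provides the first single change that can be read in this assay: replacing 2,6-dimethoxyphenyl with 2-fluorophenyl on the amide-type nitrogen in the ring gives a number 12 percentage points higher from compound 2 to compound 3 (beyond the scatter). In this pair, the two methoxy groups are therefore not needed for inhibition, and a group with fewer heavy atoms and no hydrogen-bond acceptors is accepted at this position. Nothing available explains why the step runs in this direction.

From the compounds shown here alone, it remains open whether the rise comes from adding the fluorine or from removing the two methoxy groups, a question that a plain phenyl group at this position could help separate. The compounds shown also leave open how other groups here, such as 2-chlorophenyl or a cyclohexyl ring, would compare.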